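The compounds below may be only part of what the source reports. "The series", "measured", "known", "first", "only" and "open" are said of these compounds alone.

Working notes on the series. Compound 1 `NS(=O)(=O)c1ccc(-c2nc(C(c3ccc(F)cc3)c3ccc(F)cc3)sc2CC(=O)O)cc1` is the reference point here. Going by the values given here, in an in vitro functional assay on HEK285-7 cells for antagonist activity at prostaglandin D2 receptor 2 (Homo sapiens), read by BRET and beta-arrestin recruitment (a lower number here means a smaller maximal response, a higher number a larger maximal response), compound 1 reaches 80%, which is the higher of the two values measured so far. Among the compounds with values here, the only other measured analogue, compound 2 `O=C(O)Cc1sc(NC(=O)c2ccccc2)nc1-c1ccc(Cl)cc1`, differs from compound 1 in more than one place, so no single-change step can be read from the pair; in this assay compound 2 gives 50%, a gap to compound 1 that lies beyond the usual scatter. What this gap means for any one exchange cannot be said.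

Compound 3 `O=C(O)Cc1sc(C(c2ccc(F)cc2)c2ccc(F)cc2)nc1-c1cc(F)nc(F)c1` is the next compound to be measured. It differs from compound 1 in one place only: 2,6-difluoropyridin-4-yl in place of 4-sulfamoylphenyl on an aromatic carbon. Within the data shown here, no measured pair shows this exchange, so its effect is unknown. Given that compound 1 already sits at the top of the measured range, a step downward is judged more likely than a step upward, of a size that may or may not exceed the scatter. For compound 3 the expected outcome in this assay is 65%, within 40% to 90%, a step estimated as a number 15 percentage points lower from compound 1 to compound 3 (beyond the scatter).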

Compound 3, largest response reached (reported as efficacy), in percent of the reference or control that the assay uses: 80%
Beside the measured number, compound 3's estimate is 15 percentage points below it; the measured number falls inside the stated range.
By their numbers in this assay, from the lowest: compound 2; then compounds 1 and 3 (each within the scatter of the next).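

In this assay, going by these compounds alone, the exchange of 4-sulfamoylphenyl for 2,6-difluoropyridin-4-yl, on the aromatic carbon next to the ring nitrogen and next to the ring atom that bears the carboxymethyl group, gives no change at the digits printed from compound 1 to compound 3 (within the scatter) and so provides the first single-change step. At this position, the maximal response therefore does not require the 4-sulfamoylphenyl group: a carbon-only aromatic ring with a sulfonamide gives way to a smaller pyridine ring with two fluorines and no hydrogen-bond donor, with no shift beyond the scatter. No measurement at hand accounts for this outcome.

This single step does not show whether other groups at this position, such as an unsubstituted phenyl, a 4-aminophenyl or a 4-carboxyphenyl, would also leave the response in place, nor whether the same exchange would behave alike on a different core. Going by these compounds, compound 2 differs from compound 1 and compound 3 in more than one place, so steps involving it cannot be read, and the contribution of the group at the other substituted ring carbon remains open.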